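The source may hold more compounds than are shown below. What is called first, only, known or untested is meant among the compounds shown, and "the series" means these compounds.

For the measured compounds named here, in a functional assay on MDA-MB-231 cells (Homo sapiens) for antiproliferative activity, read by MTT assay, with a stated time of 48 h (a lower number here means a stronger inhibitor of growth, a higher number a weaker inhibitor of growth), compound 2 `COC(=O)N1N=C(c2cccc(OC)c2)CC1c1cc(OC)c(OC)c(OC)c1` gives 350 nM, the lower of the two numbers so far, and compound 1 `COC(=O)N1N=C(c2ccccc2)CC1c1cc(OC)c(OC)c(OC)c1` gives 1080 nM. Compound 3 `COc1cccc(C2=NN(C(=O)OCc3ccccc3)C(c3cc(OC)c(OC)c(OC)c3)C2)c1` is recorded only as a limit, > 10000 nM. Compound 4 `COC(=O)N1N=C(c2ccc(OC)cc2)CC1c1cc(OC)c(OC)c(OC)c1` has 4-methoxyphenyl in place of 3-methoxyphenyl on a carbon with a double bond to nitrogen. Going by the values given here, the one measured change at this aromatic group, a 3.1-fold lower number from compound 1 to compound 2 (0.49 log units; beyond the scatter), was modest but beyond the scatter. The large at least 28-fold higher number from compound 2 to compound 3 (1.45 log units; beyond the scatter) lies elsewhere and does not bear on this change. A modest move towards a higher number is therefore expected in this assay, estimated as a 1.7-fold higher number from compound 2 to compound 4 (0.23 log units; within the scatter). For compound 4 the estimated value is 600 nM, with an expected range of 170 nM to 2500 nM.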

Compound 4, concentration for 50% growth inhibition: 1990 nM
Compound 4: the middle estimate sits 3.3-fold (0.52 log units) below what was measured; measured number inside the range.
By their numbers in this assay, from the lowest: compound 2; then compounds 1 and 4 (each within the scatter of the next). At a limit, above all of these: compound 3.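

In this assay, the methoxy placement on this aromatic group counts: a 5.7-fold higher number from compound 2 to compound 4 (0.75 log units; beyond the scatter) separates two compounds with the same atoms, so the 3-methoxyphenyl and 4-methoxyphenyl groups are not interchangeable at this carbon. With the methoxy as in the 4-methoxyphenyl group, a 1.8-fold higher number from compound 1 to compound 4 (0.27 log units; within the scatter) leaves no difference from the plain phenyl group beyond the scatter. Nothing measured here bears on why the two methoxy placements differ. Open, going by these compounds, is whether an ethoxy group or an amine in place of the methoxy of the 3-methoxyphenyl group would keep the number of compound 2.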